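The source may hold more compounds than are shown below. What is called first, only, known or untested is meant among the compounds shown, and "the series" means these compounds.

Working notes on the series.

Three compounds have been run in a functional assay on SK-N-SH cells (Homo sapiens) for cytotoxicity, read by MTT assay, with a stated time of 48 h; on this read-out higher numbers stand for weaker inhibition and lower numbers for stronger inhibition. Compound 1 `Cc1[nH]c2ccc([N+](=O)[O-])cc2c1C1(c2c(C)[nH]c3ccc([N+](=O)[O-])cc23)C(=O)Nc2ccccc21` gives 940 nM. Compound 3 `Cc1[nH]c2ccc([N+](=O)[O-])cc2c1C1(c2c(C)[nH]c3ccc([N+](=O)[O-])cc23)C(=O)Nc2ccc(Cl)cc21` carries a chloro group on its core where compound 1 carries hydrogen; in this assay compound 3 gives 1230 nM. Compound 2 `O=C1Nc2ccc(Cl)cc2C1(c1c[nH]c2ccc(Br)cc12)c1c[nH]c2ccc(Br)cc12` is built on a core with bromo substituents rather than the methyl and nitro groups of compounds 1 and 3; in this assay compound 2 gives 1040 nM. The difference between the core of compound 2 and the core of compound 3 is not broken down here. All three numbers sit within the usual scatter of one another, so none of them can be ranked against the others.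

The one step that can be isolated is the change from compound 3 to compound 1: hydrogen in place of chloro on an aromatic carbon
This produced a 1.3-fold lower number from compound 3 to compound 1 (0.12 log units; within the scatter).

Compound 4 `O=C1Nc2ccccc2C1(c1c[nH]c2ccc(Br)cc12)c1c[nH]c2ccc(Br)cc12` is not yet measured. It stands to compound 2 as compound 1 stands to compound 3, since the change from compound 2 to compound 4 is the same: hydrogen in place of chloro on an aromatic carbon
For the measured compounds named here, only one prior example of this change exists, and it lay within the scatter, so the expectation for compound 4 is simply that it should land near compound 2. The step from compound 2 to compound 4 in this assay is expected to be a 1.2-fold lower number from compound 2 to compound 4 (0.09 log units; within the scatter), resting on the small step seen from compound 3 to compound 1, a 1.3-fold lower number from compound 3 to compound 1 (0.12 log units; within the scatter). Compound 4 is thus estimated at 850 nM in this assay, with a likely range from 420 nM to 1700 nM.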

Compound 4, half-maximal inhibitory concentration: 930 nM
For compound 4 the middle estimate is 1.1-fold (0.04 log units) below the measured one, and the stated range covers the measured number.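

In this assay the new step is small: hydrogen in place of chloro on an aromatic carbon gives a 1.1-fold lower number from compound 2 to compound 4 (0.05 log units; within the scatter), which lies within the scatter. Set beside the earlier step, the same change reads alike on the core with methyl and nitro groups and on the core with bromo substituents: the same change on two cores in this assay, a 1.3-fold lower number (0.12 log units; within the scatter) from compound 3 to compound 1 and a 1.1-fold lower number (0.05 log units; within the scatter) from compound 2 to compound 4, 1.2-fold (0.07 log units) apart, within the scatter of two such steps. This shows that the swap of chloro for hydrogen carries from one core to the other without a detectable difference between the cores, but with both steps inside the scatter, it does not show that the change has any effect on either core, and two pairs in a single cell assay cannot establish a rule for other cores in the series.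

The compounds shown hold only chloro or hydrogen at this place on the ring, so it remains open whether a larger departure, such as an amine, a carboxylic acid or a longer chain there, would move the number beyond the scatter. The methyl and nitro groups and the bromo substituents also remain unseparated, since no pair shown differs in one of these groups alone.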